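A few compounds are considered here, and "the series" means these few. Any claim that something is new, unique, unknown or untested is made for them only; others in the source may bear on it.

Compound 3 `O=C(O)CC/C=C\CC1COC(c2cccc3ccccc23)OC1c1cccnc1` gives the lowest of the three numbers in an assay for inhibition of Thromboxane-A synthase (Homo sapiens), using microsomes (on this read-out higher numbers stand for weaker inhibition and lower numbers for stronger inhibition), with 40 nM; compound 1 `O=C(O)CC/C=C\CC1COC(c2ccc(Cl)cc2Cl)OC1c1cccnc1` gives 42 nM and compound 2 `O=C(O)CC/C=C\CC1COC(c2ccc3ccccc3c2)OC1c1cccnc1` gives 50 nM, both within the scatter of compound 3. Compound 4 `CC(C)(Oc1ccccc1)C1OCC(C/C=C\CCC(=O)O)C(c2cccnc2)O1` has not been measured in this assay. It differs from compound 3 by a group of 10 heavy atoms (9 carbon, 1 oxygen; one six-membered aromatic ring of carbon only) in place of a group of 10 heavy atoms (10 carbon; 2 six-membered aromatic rings of carbon only), on a saturated ring carbon. The steps already seen at this position all concern one aromatic group in place of another: a 1.2-fold higher number from compound 1 to compound 2 (0.08 log units; within the scatter), a 1.1-fold lower number from compound 1 to compound 3 (0.02 log units; within the scatter) and a 1.3-fold lower number from compound 2 to compound 3 (0.10 log units; within the scatter). None of them moved the number beyond the scatter, which suggests that this position tolerates exchange of the group that sits between the two ring oxygen atoms. Among the measured compounds shown here, the group entering in compound 4, however, carries its aromatic ring through an oxygen and a branched carbon rather than directly, so the earlier steps bear on it only loosely. Compound 4 is therefore expected to show a step of about a 1.5-fold higher number from compound 3 to compound 4 (0.18 log units; within the scatter), with the uncertainty widened because the change goes beyond the aryl-for-aryl swaps seen so far. The estimate for compound 4 is 60 nM, within a range of 20 nM to 200 nM.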

Compound 4, half-maximal inhibitory concentration: 52 nM
Estimate against measurement, compound 4: 1.2-fold (0.06 log units) above; low and high end bracket the measured number.
By their numbers in this assay, from the lowest: compounds 3, 1, 2 and 4 (each within the scatter of the next).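

In this assay, the position between two ring oxygen atoms also accepts a group that carries its single aromatic ring through an oxygen and a branched carbon, since the exchange for naphthalen-1-yl stays within the scatter (a 1.3-fold higher number from compound 3 to compound 4 (0.11 log units; within the scatter)). The same holds when this group is compared with the other two aromatic groups (a 1.0-fold higher number from compound 2 to compound 4 (0.02 log units; within the scatter)) and (a 1.2-fold higher number from compound 1 to compound 4 (0.09 log units; within the scatter)), so among these four compounds the tolerance is no longer limited to aromatic rings attached directly to the ring carbon. Nothing available explains this result.

On these data alone, all four groups at this position contain a six-membered aromatic ring of carbon only, so the effect of an amine, a carboxylic acid or a plain methyl there remains open. Also open, as far as these compounds go, is how the number responds to changes at the pyridin-3-yl group or the 5-carboxypent-2-en-1-yl group, which all four compounds share.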